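The compounds below may be only part of what the source reports. "The series", "measured", "known", "first", "only" and "open" are said of these compounds alone.

Measured compounds in a functional assay on MCF7 cells (Homo sapiens) for cytotoxicity, read by MTT assay, with a stated time of 96 h; on this read-out lower numbers stand for stronger inhibition and higher numbers for weaker inhibition:
- compound 1 `COc1cc(C(=O)c2cn(-c3ccccc3)cc2-c2ccc(N)cc2)cc(OC)c1OC`: 9 nM
- compound 2 `COc1cc(C(=O)c2cn(-c3ccccc3N)cc2-c2ccccc2)cc(OC)c1OC`: 3800 nM
- compound 3 `COc1cccc(-n2cc(C(=O)c3cc(OC)c(OC)c(OC)c3)c(-c3ccccc3)c2)c1`: 500 nM

Compound 2 stands highest of the three numbers in this assay: its nearest neighbour is compound 3, and compound 1 lies far below it. Compound 4 `COc1cc(C(=O)c2cn(-c3ccc(Cl)cc3)cc2-c2ccccc2)cc(OC)c1OC` differs from compound 2 in one place: 4-chlorophenyl in place of 2-aminophenyl on an aromatic nitrogen. Among the compounds with values here, one measured step bears on this change, since it too swaps the 2-aminophenyl for another substituted phenyl on the same aromatic nitrogen: a 7.6-fold lower number from compound 2 to compound 3 (0.88 log units; beyond the scatter). Within the data shown here, no measured compound carries a 4-chlorophenyl, so the size of that part is unknown. A modest step downward is therefore expected, a 6.3-fold lower number from compound 2 to compound 4 (0.80 log units; beyond the scatter). Compound 4 is estimated at 600 nM, with a range from 150 nM to 3000 nM.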

Compound 4, half-maximal inhibitory concentration: 140 nM
The estimate for compound 4 lay 4.3-fold (0.63 log units) above the measured number; the whole stated range lies above it.
By their numbers in this assay, from the lowest: compound 1; then compound 4; then compound 3; then compound 2.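

Within the data shown here, on the aromatic nitrogen, the choice of phenyl group matters more than the earlier compounds showed: in this assay, replacing 2-aminophenyl with 4-chlorophenyl gives a 27-fold lower number from compound 2 to compound 4 (1.43 log units; beyond the scatter), a larger step than the one to 3-methoxyphenyl. The two replacements also differ from each other, with a 3.6-fold lower number from compound 3 to compound 4 (0.55 log units; beyond the scatter), so losing the 2-aminophenyl is not the whole story. Nothing measured here explains these differences. As far as these compounds go, it remains open whether a 4-fluorophenyl or 4-methoxyphenyl group would match 4-chlorophenyl, and whether 4-chlorophenyl would act the same way on the core of compound 1.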